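The source may hold more compounds than are shown below. What is called first, only, known or untested is meant among the compounds shown, and "the series" means these compounds.

Measured compounds:
- compound 1 `Cc1ccc(S(=O)(=O)c2cnc3cc(F)ccc3c2N2CCC(C)CC2)cc1Cl`: 93%
- compound 2 `Cc1ccc2ncc(S(=O)(=O)c3ccc(C)c(Cl)c3)c(N3CCC(C)CC3)c2c1`: 91%
- compound 3 `Cc1ccc(S(=O)(=O)c2cnc3cc(Cl)ccc3c2N2CCC(C)CC2)cc1Cl`: 89%

In an assay on isolated protein for displacement of a labelled ligand from metabotropic glutamate receptor 5 (Homo sapiens), with a stated time of 60 min, tested at 1 uM (on this read-out lower numbers stand for less inhibition and higher numbers for more inhibition at the one concentration tested (going by the name of the read-out)), compound 1 gives 93%, the highest of the three numbers, though the gaps are small: compound 2 sits nearest and compound 3 furthest, both within the scatter. Within the data shown here, the only single-place step measured is a number 4 percentage points lower from compound 1 to compound 3 (within the scatter), which concerns a halogen on the shared core and not the sulfonyl aryl.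

Compound 4 `Cc1ccc(S(=O)(=O)c2cnc3cc(F)ccc3c2N2CCC(C)CC2)cc1` differs from compound 1 in one place: hydrogen in place of chloro on an aromatic carbon. Among the measured compounds shown here, no measured step touches this position, so there is nothing direct to lean on; the one measured step shows only that a halogen exchange elsewhere left this assay essentially unchanged. Given that all three measured compounds, carrying the 3-chloro-4-methylphenyl group, sit at high inhibition, the loss of the chloro is expected to cost at most a modest amount, with a step of a number 9 percentage points lower from compound 1 to compound 4 (within the scatter) expected that stays near the scatter. For compound 4 the estimate in this assay is 84%, with a range from 62% to 96%.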

Compound 4, a percentage reported as inhibition, at one concentration (the size of the read-out at that concentration, not a potency): 88%
Compound 4: the middle estimate sits 4 percentage points below what was measured; the measured number falls inside the stated range.
By their numbers in this assay, from the lowest: compounds 4, 3, 2 and 1 (each within the scatter of the next).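

Hydrogen in place of chloro on the aromatic carbon ortho to the methyl group gives a number 5 percentage points lower from compound 1 to compound 4 (within the scatter) in this assay. Among these compounds, this is the first measured change on the sulfonyl aryl, since the earlier compounds all carry the 3-chloro-4-methylphenyl group and could not show whether their high inhibition required the chloro; with the 4-methylphenyl group, compound 4 still gives 88% at the one concentration tested, so the chloro is not required for high inhibition here. Nothing at hand explains why this position accepts the change.

On these data alone, whether a methoxy, a nitrile or a carboxylic acid at this carbon would keep inhibition at this level remains open, as does the effect of replacing the neighbouring methyl group. A percentage at one concentration also leaves open any difference in potency between compound 1 and compound 4.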